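This account rests on a few compounds, and the source may have more. Where it says the series, first, only, none or still open, it means among the compounds named here.

Measured so far in a functional assay on HCT-116 cells (Homo sapiens) for inhibition, read by MTT assay, with a stated time of 2 days; a lower number here means a stronger inhibitor of growth, a higher number a weaker inhibitor of growth:
- compound 1 `Nc1ccccc1NC(=O)CCCNCC(=O)Nc1ccc(Cl)cc1` gives 45000 nM
- compound 2 `Nc1ccccc1NC(=O)CCCNCC(=O)Nc1ccc(Br)cc1` gives 55500 nM
- compound 3 `Nc1ccccc1NC(=O)CCCNCC(=O)Nc1cccc([N+](=O)[O-])c1` gives 22500 nM

Only one gap among these three exceeds the usual scatter of repeat measurements. It is a 2.5-fold lower number from compound 2 to compound 3 (0.39 log units; beyond the scatter) and counts as modest. Both a 1.2-fold higher number from compound 1 to compound 2 (0.09 log units; within the scatter) and a 2.0-fold lower number from compound 1 to compound 3 (0.30 log units; within the scatter) stay within the scatter. Compound 3 therefore stands clearly apart from compound 2 only, and it cannot be told apart from compound 1.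

The next step leads to compound 4 `Nc1ccccc1NC(=O)CCCNCC(=O)Nc1cc(Cl)ccc1Cl` with 2,5-dichlorophenyl in place of 3-nitrophenyl on an amide-type nitrogen.

Read in reverse, a 2.0-fold lower number from compound 1 to compound 3 (0.30 log units; within the scatter) and a 2.5-fold lower number from compound 2 to compound 3 (0.39 log units; beyond the scatter) are the nearest guides, since each joins 3-nitrophenyl to a halogen-bearing phenyl on that same nitrogen. Both suggest a somewhat higher number once 3-nitrophenyl is gone. For the measured compounds named here, no measured compound carries 2,5-dichlorophenyl, so this guide is a loose one. A small rise of similar size is expected, and the expected outcome is a 1.8-fold higher number from compound 3 to compound 4 (0.25 log units; within the scatter) and no more than that. Compound 4 is estimated at 40000 nM with 18000 nM to 85000 nM as the expected range.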

Compound 4, concentration for total growth inhibition: 78000 nM
Beside the measured number, compound 4's estimate is 2.0-fold (0.29 log units) below it; the range from low to high includes it.
By their numbers in this assay, from the lowest: compounds 3, 1, 2 and 4 (each within the scatter of the next, the first and the last beyond it).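

In this assay, for the compounds shown here, a 3.5-fold higher number from compound 3 to compound 4 (0.54 log units; beyond the scatter) is the second step beyond the scatter that involves compound 3, after the one from the 4-bromophenyl compound, so the 3-nitrophenyl compound now stands clearly apart from two of the three halogen-bearing compounds, though still not from compound 1. Going by these compounds alone, the 2,5-dichlorophenyl group, seen here for the first time on this amide-type nitrogen, cannot be told apart from the rings with a single halogen: both a 1.4-fold higher number from compound 2 to compound 4 (0.15 log units; within the scatter) and a 1.7-fold higher number from compound 1 to compound 4 (0.24 log units; within the scatter) stay within the scatter, so a ring with two chlorines reads the same as one with a single chlorine or bromine. Nothing available gives a reason for the gap between compound 3 and compound 4.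

The compounds shown leave open how a plain phenyl, a 4-nitrophenyl or a 3-chlorophenyl would read on this nitrogen, so the effect of the nitro group cannot be separated from the effect of where it sits on the ring. They also keep the rest of the core fixed, leaving open what a longer chain, or a hydroxamic acid in place of the 2-aminophenyl amide, would do to these high numbers.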